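Adding a Methoxyphenyl Group to a Thiosemicarbazone

The source may report more compounds than this note shows. Statements on the series, on what has been measured and on what is new or still open speak of the compounds shown alone.

Compound 1 `NC(=S)N/N=C/c1ccc2ccccc2n1` is the simplest member of this small set: a thiosemicarbazone whose terminal nitrogen carries only hydrogen. In a functional assay on HeLa cells (Homo sapiens) for antiproliferative activity, read by sulforhodamine B assay, with a stated time of 72 h (on this read-out lower numbers stand for stronger inhibition and higher numbers for weaker inhibition), compound 1 gives 960 nM. Two companions have been measured. Compound 2 `CN(C)C(=S)N/N=C/c1cnc2ccccc2n1`, which carries two methyl groups on that nitrogen and a slightly different core, gives 750 nM in this assay, a number within the scatter of compound 1. Compound 3 `CC(C)c1cccc(C(C)C)c1NC(=S)N/N=C/c1ccc2ccccc2n1`, which carries a 2,6-diisopropylphenyl group on the nitrogen, gives 16400 nM, the highest of the three numbers and far beyond the scatter from compound 1. Compound 1 therefore stands second highest of the three, close to compound 2 and well apart from compound 3.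

Compound 4 `COc1ccc(NC(=S)N/N=C/c2ccc3ccccc3n2)cc1` has not been measured. It differs from compound 1 in one place: 4-methoxyphenyl in place of hydrogen on an amide-type nitrogen. Within the data shown here, no measured pair tests exactly this change. Compound 3 carries a different aryl group on the same nitrogen and gives a much higher number than compound 1, so a step upward from compound 1 is expected for compound 4, estimated as a 2.6-fold higher number from compound 1 to compound 4 (0.42 log units; beyond the scatter), though a less severe one. Compound 4 is expected to give about 2500 nM in this assay, estimated between 600 nM and 10000 nM.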

Compound 4, half-maximal inhibitory concentration: 72600 nM
For compound 4 the middle estimate is 29-fold (1.46 log units) below the measured one; the whole stated range lies below it.
By their numbers in this assay, from the lowest: compounds 2 and 1 (each within the scatter of the next); then compound 3; then compound 4.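

Putting 4-methoxyphenyl in place of hydrogen on the amide-type nitrogen gives a 76-fold higher number from compound 1 to compound 4 (1.88 log units; beyond the scatter) in this assay, so at this position, on this core, this change brings a large loss of inhibition. A bulky pair of isopropyl groups on the aryl ring is therefore not needed for a high number: compound 3 gives 16400 nM and compound 4, which has none, gives 72600 nM in the same assay. Nothing available here explains why this step is so large.

On these data alone, whether the loss comes with the aryl ring itself or with its methoxy group stays open, and a plain phenyl group on this nitrogen would separate the two. A 4-aminophenyl or 4-carboxyphenyl group, or a short chain such as ethyl, could show whether any substituent here keeps the number near that of compound 1.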